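Swapping the Hydroxypropyl Side Chain for a Dihydroxyethyl One

The source may hold more compounds than are shown below. What is called first, only, known or untested is meant among the compounds shown, and "the series" means these compounds.

Three compounds were measured in a functional assay on MCF7 cells (Homo sapiens) for antiproliferative activity, read by MTT assay, with a stated time of 24 h, tested at 12.5 uM; a higher number here means a weaker effect of the compound at the concentration tested, a lower number a stronger effect:
Compound 1, `OC(CCn1nc2c(Br)c(Br)c(Br)c(Br)c2n1)c1cccc(Br)c1`, gives 81%.
Compound 2, `C[C@H](O)CCn1nc2c(Br)c(Br)c(Br)c(Br)c2n1`, gives 112%.
Compound 3, `OC(CCn1nc2c(Br)c(Br)c(Br)c(Br)c2n1)c1ccc(Cl)cc1`, gives 90%.

Compound 2 has the highest number of the three, beyond the scatter above both compound 3 and compound 1, so it shows the weakest effect here. Compound 4, `OCC(O)Cn1nc2c(Br)c(Br)c(Br)c(Br)c2n1`, differs from compound 2 by 1,2-dihydroxyethyl in place of 2-hydroxypropyl on a saturated chain carbon bound to an aromatic nitrogen. Within the data shown here, the only measured step, a number 9 percentage points higher from compound 1 to compound 3 (within the scatter), concerns the aryl group and not this part of the side chain, so it does not bear on the change; no measured pair shows what this swap does. A small step is therefore expected: a number 7 percentage points lower from compound 2 to compound 4 (within the scatter) is the estimate, with no clear direction. Compound 4 is expected at 105%, between 85% and 120%.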

Compound 4, a percentage reported as activity, at one concentration (the size of the read-out at that concentration, not a potency): 145%
Estimate against measurement, compound 4: 40 percentage points below; the whole stated range lies below it.
By their numbers in this assay, from the lowest: compounds 1 and 3 (each within the scatter of the next); then compound 2; then compound 4.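

In this assay, this side chain proves sensitive to a small edit: 1,2-dihydroxyethyl in place of 2-hydroxypropyl gives a number 33 percentage points higher from compound 2 to compound 4 (beyond the scatter), a move towards a weaker effect. Both groups hold 4 heavy atoms, so the swap leaves that count unchanged while replacing 1 hydrogen-bond donor with 2 and removing the defined stereocentre. No measurement shown explains the step.

The compounds leave open which of these differences matters. They also leave open how an amine or a carboxylic acid would behave at this place on the chain.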